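Replacing an aryl amide with a chloropyridyl amide

This account rests on a few compounds, and the source may have more. Where it says the series, first, only, none or still open, it means among the compounds named here.

Compound 2: `Cc1cc(Cl)ccc1C(=O)Nc1ccc(Cl)c(-c2nnc3c(Cl)cccn23)c1` — > 100000 nM
Compound 1: `O=C(Nc1ccc(Cl)c(-c2nnc3c(Cl)cccn23)c1)c1ccc(C(F)(F)F)cc1F` — > 100000 nM

The account follows one change in the amide part of a shared core. In a functional assay on A549 cells (Homo sapiens) for antiproliferative activity, read by MTT assay, with a stated time of 72 h (on this read-out lower numbers stand for stronger inhibition and higher numbers for weaker inhibition), compound 2 gives > 100000 nM, which is a limit of the assay and not a number. In this assay compound 1 likewise gives > 100000 nM, again a limit rather than a number. Where compound 2 stands can therefore only be described by the limit of > 100000 nM in this assay, at which 2 of the 2 values shown sit, with no measured step between the two compounds to set a scale.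

Compound 3 is `O=C(Nc1ccc(Cl)c(-c2nnc3c(Cl)cccn23)c1)c1cccnc1Cl`. Compared with compound 2 it carries 2-chloropyridin-3-yl in place of 4-chloro-2-methylphenyl on a carbonyl carbon. No step between measured compounds is known, so the size of the change cannot be read from anything shown. With both known values sitting at a limit, compound 3 is expected to remain in the same region, and the step of a number no higher from compound 2 to compound 3 (the limit leaves the size open) is expected to be none beyond the scatter. For compound 3 in this assay the estimate is 100000 nM, within a range from 30000 nM to 300000 nM, and most likely again reported as a limit.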

Compound 3, half-maximal inhibitory concentration: 35800 nM
Estimate against measurement, compound 3: 2.8-fold (0.45 log units) above, within the range that was stated.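

In this assay, putting 2-chloropyridin-3-yl in place of 4-chloro-2-methylphenyl on the carbonyl carbon gives an at least 2.7-fold lower number from compound 2 to compound 3 (0.44 log units; beyond the scatter), the first step shown that gives this part of the shared core any scale. Compound 3 gives 35800 nM, the only actual number among the compounds shown, which means that a change at this place alone can bring the read-out to a measured number. The value of compound 2 is a limit of the assay and not a number, so the step has a known minimum but no known size: the limit of > 100000 nM in this assay, at which 2 of the 3 values shown sit.

The exchange replaces a ring carbon with nitrogen and removes the methyl in one move, and the compounds shown do not separate these two differences, so neither can be tied to the lower number. They also leave open how this assay would read with a pyridine carrying an amine in place of the chlorine, or with a carboxylic acid or a longer chain on the ring attached to this carbonyl carbon.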